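Shifting the amide aryl group on a flavonol scaffold

This account rests on a few compounds, and the source may have more. Where it says the series, first, only, none or still open, it means among the compounds named here.

Compound 1 `O=C(Nc1cccc(-c2oc3cc(-c4ccc(F)cc4)ccc3c(=O)c2O)c1)c1ccc(F)cc1`: 9280 nM
Compound 2 `O=C(Nc1cccc(-c2oc3cc(-c4ccc(F)cc4)ccc3c(=O)c2O)c1)c1ccc(Cl)nc1`: 4610 nM

Both compounds were tested in a functional assay on HepG2 cells (Homo sapiens) for antiproliferative activity, read by CCK-8 assay, with a stated time of 72 h; on this read-out lower numbers stand for stronger inhibition and higher numbers for weaker inhibition. Compound 2 sits alongside compound 1, the two values lying within the scatter of each other: a 2.0-fold lower number from compound 1 to compound 2 (0.30 log units; within the scatter). Compound 3 `O=C(Nc1cccc(-c2oc3cc(-c4ccc(F)cc4)ccc3c(=O)c2O)c1)c1cc(F)cc(F)c1` carries a further variation at the same position: 3,5-difluorophenyl in place of 6-chloropyridin-3-yl on a carbonyl carbon. For the measured compounds named here, the only step that bears on this change is the one from compound 1 to compound 2, and it did not rise above the scatter. The expectation for compound 3 in this assay is therefore a value close to compound 2, with a 1.4-fold higher number from compound 2 to compound 3 (0.15 log units; within the scatter). Compound 3 is estimated at 6500 nM, within 2500 nM to 17000 nM.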

Compound 3, half-maximal inhibitory concentration: 4960 nM
Beside the measured number, compound 3's estimate is 1.3-fold (0.12 log units) above it, within the range that was stated.
By their numbers in this assay, from the lowest: compounds 2, 3 and 1 (each within the scatter of the next).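

In this assay, 3,5-difluorophenyl on the carbonyl carbon reads like both earlier groups (a 1.1-fold higher number from compound 2 to compound 3 (0.03 log units; within the scatter)) and (a 1.9-fold lower number from compound 1 to compound 3 (0.27 log units; within the scatter)), with both steps within the scatter. Three different aromatic rings at this position, one holding a ring nitrogen and a chlorine and two holding only fluorine, therefore cannot be told apart here. No measurement at hand gives a reason for this sameness. Still open, as far as these compounds go, is whether a non-aromatic group here, such as a cyclohexyl ring or a longer alkyl chain, would shift the number beyond the scatter. The same holds for a phenyl ring bearing an amine or a carboxylic acid.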